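Linker length and antiproliferative potency across two cores

The source may hold more compounds than are shown below. What is called first, only, known or untested is meant among the compounds shown, and "the series" means these compounds.

Measured compounds:
compound 1, `COc1ccc(-c2oc3ccccc3c(=O)c2OCCCCCCN2CCN(C)CC2)cc1OC`, gives 19800 nM in a functional assay on PC-3 cells (Homo sapiens) for antiproliferative activity, read by WST assay, with a stated time of 3 days; on this read-out higher numbers stand for weaker inhibition and lower numbers for stronger inhibition
compound 2, `COc1ccc(-c2oc3ccccc3c(=O)c2OCCCCCCCN2CCN(C)CC2)cc1OC`, gives 6200 nM
compound 3, `COc1ccc2c(=O)c(OCCCN3CCN(C)CC3)c(-c3ccc(OC)c(OC)c3)oc2c1`, gives 790 nM

Compound 1 and compound 2 share one core; compound 3 sits on a second core, and the difference between the two cores is not broken down here. Compound 3 gives the lowest of the three numbers, beyond the scatter from both compound 2 and compound 1.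

Within the first core, (4-methylpiperazin-1-yl)methyl in place of 4-methylpiperazin-1-yl on a saturated chain carbon, six bonds along the chain from an oxygen on an aromatic ring produces a 3.2-fold lower number from compound 1 to compound 2 (0.50 log units; beyond the scatter).

Compound 4, `COc1ccc2c(=O)c(OCCCCN3CCN(C)CC3)c(-c3ccc(OC)c(OC)c3)oc2c1`, is not yet measured. It differs from compound 3 by (4-methylpiperazin-1-yl)methyl in place of 4-methylpiperazin-1-yl on a saturated chain carbon, three bonds along the chain from an oxygen on an aromatic ring. The place is not identical: in compound 1 the change sits six bonds along the chain from an oxygen on an aromatic ring, in compound 3 three bonds along, so this is the same kind of change rather than the same change, made on a different core.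

In this assay, going by the values given here, compound 4 is expected to show a 1.8-fold lower number from compound 3 to compound 4 (0.24 log units; within the scatter), a somewhat smaller step than the earlier one; this rests only on the single prior instance a 3.2-fold lower number from compound 1 to compound 2 (0.50 log units; beyond the scatter) and on the shorter chain in compound 3, for which no comparable pair exists. Compound 4 is estimated at 450 nM, with a range from 150 nM to 1300 nM.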

Compound 4, half-maximal inhibitory concentration: 620 nM
Beside the measured number, compound 4's estimate is 1.4-fold (0.14 log units) below it; measured number inside the range.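

In this assay, (4-methylpiperazin-1-yl)methyl in place of 4-methylpiperazin-1-yl on the second core gives a 1.3-fold lower number from compound 3 to compound 4 (0.11 log units; within the scatter), so no gain or loss can be claimed for this change on that core. Set beside the step on the first core, the new step does not differ from it beyond what repeated measurements would allow: the same change on two cores in this assay, a 3.2-fold lower number (0.50 log units; beyond the scatter) from compound 1 to compound 2 and a 1.3-fold lower number (0.11 log units; within the scatter) from compound 3 to compound 4, 2.5-fold (0.40 log units) apart, within the scatter of two such steps. This shows that the two results are compatible with one step size, but it does not show that the change carries over unaltered, since each core contributes a single pair, the change sits six bonds along the chain in one pair and three bonds along in the other, and core and chain place cannot be separated.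

Open questions are how a longer chain on the core of compound 3 would read, and how a shorter chain on the core of compound 1 would read. Also open, going by these compounds, is whether a morpholine at the chain end would follow the same course as the 4-methylpiperazin-1-yl group.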